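The compounds below may be only part of what the source reports. "The series", "measured", "known", "first", "only" and "open" are said of these compounds alone.

Measured so far in a functional assay on the whole organism for inhibition, with Mus musculus as the target, with a stated time of 1 h, at a dose of 100 mg/kg by the intraperitoneal route; a lower number here means less inhibition, a higher number more inhibition at the dose given (going by the name of the read-out):

- compound 1, `Cc1ccccc1NC(=O)Nn1c(C)nc2ccccc2c1=O`: compound 1 gives 51%
- compound 2, `Cc1nc2ccccc2c(=O)n1NC(=O)Nc1ccc(I)cc1`: compound 2 gives 53%
- compound 3, `Cc1nc2ccccc2c(=O)n1NC(=O)Nc1ccc(Br)cc1`: compound 3 gives 51%

Compound 3 stands level with compound 1, the two values showing no change at the digits reported, and the step of a number 2 percentage points lower from compound 2 to compound 3 (within the scatter) is within the scatter; the three numbers cannot be told apart.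

Compound 4, `COc1ccc(NC(=O)Nn2c(C)nc3ccccc3c2=O)cc1`, differs from compound 3 in one place: methoxy in place of bromo on an aromatic carbon.

Going by the values given here, three measured steps bear on this. The exchanges of the whole aryl group on the amide-type nitrogen, a number 2 percentage points higher from compound 1 to compound 2 (within the scatter) and no change at the digits printed from compound 1 to compound 3 (within the scatter), and the halogen exchange on the aromatic carbon, a number 2 percentage points lower from compound 2 to compound 3 (within the scatter), are all within the scatter. Nothing measured here shows that the group para to a large group moves the inhibition. The step is therefore expected to be a number 1 percentage points lower from compound 3 to compound 4 (within the scatter), that is, none beyond the scatter. For compound 4 the estimate in this assay is 50%, with a range from 38% to 62%.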

Compound 4, a percentage reported as inhibition, in the whole organism at one dose (the size of the read-out at that dose, not a potency): 42%
The estimate for compound 4 lay 8 percentage points above the measured number; low and high end bracket the measured number.
By their numbers in this assay, from the lowest: compounds 4, 1, 3 and 2 (each within the scatter of the next, the first and the last beyond it).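

In this assay, the position para to a large group gives its first step beyond the scatter: methoxy in place of iodo (a number 11 percentage points lower from compound 2 to compound 4 (beyond the scatter)), a modest step. Methoxy in place of bromo (a number 9 percentage points lower from compound 3 to compound 4 (within the scatter)) and 4-methoxyphenyl in place of 2-methylphenyl (a number 9 percentage points lower from compound 1 to compound 4 (within the scatter)) stay within the scatter, so compound 4 separates from compound 2 alone and cannot be told apart from compound 1 or compound 3. Nothing at hand accounts for the step from iodo to methoxy.

Open, on these data alone, is whether an amine or a carboxylic acid at this place would also separate from compound 2, or would move the number further. With a single dose and a single time, these numbers also leave potency in this series open.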